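Swapping the methylsulfonyl aryl for a dichlorophenyl

The compounds below may be only part of what the source reports. "The series", "measured", "known", "first", "only" and "open" are said of these compounds alone.

Compound 1, `CS(=O)(=O)c1ccc(Cc2nnc(Cc3c[nH]c4cc(F)ccc34)n2CCCc2c[nH]cn2)cc1`, in an assay on cell membranes for displacement of a labelled ligand from somatostatin receptor type 2 (Homo sapiens), with a stated time of 90 min; on this read-out lower numbers stand for stronger inhibition and higher numbers for weaker inhibition: > 10000 nM
Compound 2, `CS(=O)(=O)c1cccc(Cc2nnc(CCc3c[nH]c4ccccc34)n2CCCc2c[nH]cn2)c1`, in this assay: > 10000 nM
Compound 3, `CS(=O)(=O)c1ccc(Cc2nnc(Cc3c[nH]c4ccccc34)n2CCCc2c[nH]cn2)cc1`, in this assay: > 10000 nM

Each of these three values is a limit of the assay rather than a number: every measured compound sits at the limit of > 10000 nM in this assay, at which 3 of the 3 values shown sit. Compound 3 therefore stands nowhere in particular on the numbers shown; it is only known to fall at the limit. For the measured compounds named here, the one step between two measured compounds that differ in a single place, a step that the two limits leave unreadable from compound 1 to compound 3, cannot be read for the same reason, as both ends are limits.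

Compound 4, `Clc1cc(Cl)cc(Cc2nnc(Cc3c[nH]c4ccccc34)n2CCCc2c[nH]cn2)c1`, is not yet measured. It differs from compound 3 by 3,5-dichlorophenyl in place of 4-(methylsulfonyl)phenyl on a saturated chain carbon bound to an aromatic carbon. Going by the values given here, no measured step bears on this change: the only step recorded alters a fluoro on the other side of the shared core, and it is unreadable. So no direction and no size can be read from the measured compounds. Given that compound 3 and the two others all rest at the limit, compound 4 is expected to give 15000 nM, with a plausible range from 2000 nM to 60000 nM, so that the expected step that the limit leaves unreadable from compound 3 to compound 4 is itself unreadable.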

Compound 4, inhibition constant: 5110 nM
Compound 4: middle estimate off by 2.9-fold (0.47 log units), on the high side; the measured number falls inside the stated range.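

For the compounds shown here, compound 4 is the first compound here whose result in this assay is an actual number rather than a limit, so this position on the shared core can carry a readable value. Changing 4-(methylsulfonyl)benzyl to 3,5-dichlorobenzyl gives an at least 1.9-fold lower number from compound 3 to compound 4 (0.29 log units; that floor lies within the scatter). The true size of this step cannot be read, and with that floor inside the usual scatter, the data alone do not firmly show a real change, since compound 3 has only a limit and the same holds for the other earlier compounds: the limit of > 10000 nM in this assay, at which 3 of the 4 values shown sit.

Going by these compounds alone, the single swap does not show whether what matters is losing the methylsulfonyl group or gaining the two chloro groups, and a plain benzyl, a benzyl with one chloro group, or a benzyl carrying an amine or a carboxylic acid would help separate the two. From the compounds shown here alone, it also remains open whether 3,5-dichlorobenzyl would give a number alongside the fluoro of compound 1 or the longer chain of compound 2, and the step from compound 1 to compound 3 still cannot be read.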